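Cytotoxicity in the series: from compound 3 to compound 4

This account rests on a few compounds, and the source may have more. Where it says the series, first, only, none or still open, it means among the compounds named here.

These notes concern the cyclopropenylidene-bearing compounds carrying a diol side chain, tested in an ADME assay on BCBL1 cells (Homo sapiens) for cytotoxicity, with a stated time of 7 days; on this read-out lower numbers stand for higher toxicity in this test and higher numbers for lower toxicity in this test. Compound 1 `Nc1nc(NC2CC2)c2ncn(/C=C3/CC3(CO)CO)c2n1` gives 71500 nM in this assay. Compound 3 `Nc1nc(NC2CCCC2)c2ncn(/C=C3/CC3(CO)CO)c2n1`, in which cyclopentyl stands in place of cyclopropyl on a nitrogen on an aromatic ring, gives 71700 nM in this assay; the step of a 1.0-fold higher number from compound 1 to compound 3 (0.00 log units; within the scatter). Compound 2 `Nc1nc2c(ncn2/C=C2/CC2(CO)CO)c(=O)[nH]1` gives only a limit in this assay, > 20000 nM, so no number is known for it (the limit of > 20000 nM in this assay, at which 1 of the 3 values shown sits). Among the two numbers, compound 3 stands with the higher one, but its gap to compound 1 is within the scatter, so the two are not ordered.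

Compound 4 `CCCCSc1nc(N)nc2c1ncn2/C=C1/CC1(CO)CO` is not yet measured. It differs from compound 3 as follows: butylsulfanyl in place of cyclopentylamino on an aromatic carbon. Among the compounds with values here, the only measured step, from compound 1 to compound 3, changes the group at this same aromatic carbon and stays within the scatter, but it exchanges one cycloalkylamino for another, whereas here an amine is replaced by a thioether. Within the data shown here, that step is the sole guide, and it points to no change beyond the scatter. Compound 4 is therefore expected to give about 65000 nM in this assay, between 25000 nM and 180000 nM, which corresponds to an expected step of a 1.1-fold lower number from compound 3 to compound 4 (0.04 log units; within the scatter).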

Compound 4, half-maximal cytotoxic concentration: > 20000 nM
Compound 4: only a limit was reported; the forecaster's own chance of this, stated with the estimate: 25%; the middle value lies beyond the limit too.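

In this assay compound 4 gives > 20000 nM, which is a limit and not a number. The steps to compound 4 from compound 3 and from compound 1 therefore cannot be read. The compounds shown leave open how butylsulfanyl compares with cyclopentylamino or cyclopropylamino on this aromatic carbon, with values resting at: the limit of > 20000 nM in this assay, at which 2 of the 4 values shown sit.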